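Para Group Exchange on the Phenoxy Ring

This account rests on a few compounds, and the source may have more. Where it says the series, first, only, none or still open, it means among the compounds named here.

Compound 1 `Cc1nn(C)c(Oc2ccc(F)cc2)c1/C=N\OCc1c(Cl)c(-c2ccc(F)cc2)nn1C` and compound 2 `Cc1nn(C)c(Oc2ccc(Cl)cc2)c1/C=N\OCc1c(Cl)c(-c2ccc(F)cc2)nn1C` share one core and differ only in the halogen on the phenoxy ring. In a functional assay on SMMC-7721 cells (Homo sapiens) for inhibition, read by MTT assay, with a stated time of 72 h, tested at 25 uM (a lower number here means less inhibition, a higher number more inhibition at the concentration tested (going by the name of the read-out)), compound 1 gives 80% and compound 2 gives 80%; the step of no change at the digits printed from compound 1 to compound 2 (within the scatter) stays within the scatter. Compound 2 therefore stands level with compound 1 at the digits shown. Compound 3 `Cc1ccc(Oc2c(/C=N\OCc3c(Cl)c(-c4ccc(F)cc4)nn3C)c(C)nn2C)cc1` carries the change (methyl in place of chloro on an aromatic carbon). Among the compounds with values here, the only measured step, no change at the digits printed from compound 1 to compound 2 (within the scatter), exchanged one group on the same ring of carbon only without moving the read-out, so for compound 3 a step of like size is expected, a number 4 percentage points lower from compound 2 to compound 3 (within the scatter), within the scatter. Compound 3 is expected to give 76% in this assay, between 58% and 90%.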

Compound 3, a percentage reported as inhibition, at one concentration (the size of the read-out at that concentration, not a potency): 80%
For compound 3 the middle estimate is 4 percentage points below the measured one, and the stated range covers the measured number.
By their numbers in this assay, from the lowest: compounds 1, 2 and 3 (each within the scatter of the next).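

In this assay the 4-methylphenoxy group reads like the halogen-bearing groups, with no change at the digits printed from compound 2 to compound 3 (within the scatter) for methyl in place of chloro and no change at the digits printed from compound 1 to compound 3 (within the scatter) for methyl in place of fluoro. This place on the ring, para to a large group, thus now holds a carbon group as well as two halogens without a step beyond the scatter. No available evidence explains this level read-out. As far as these compounds go, how an amine, a carboxylic acid or a longer chain would read at this place remains open. So does whether these compounds would stay level at other concentrations.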